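The compounds below may be only part of what the source reports. "The series", "measured", "known", "first", "only" and "open" are said of these compounds alone.

Measured so far:
compound 1, `CC#C[C@@H](CC(=O)O)c1ccc(OC[C@H]2COc3ccc(Cl)cc3O2)cc1`, 50 nM
compound 2, `CC#C[C@@H](CC(=O)O)c1ccc(OC[C@H]2COc3ccc(Br)cc3O2)cc1`, 210 nM
compound 3, `CC#C[C@@H](CC(=O)O)c1ccc(OC[C@H]2COc3cc(Cl)c(Cl)cc3O2)cc1`, 150 nM

Of the compounds shown here, three have been tested in a functional assay on HEK293 cells for agonist activity at Free fatty acid receptor 1 (Homo sapiens), read by fluorescence and calcium flux, with a stated time of 10 min; a lower number here means that less compound is needed, a higher number that more compound is needed for the effect. Compound 1 gives 50 nM. Compound 2 gives 210 nM, and compound 3 gives 150 nM. The change from compound 1 to compound 2 is bromo in place of chloro on an aromatic carbon, and it brought a 4.2-fold higher number from compound 1 to compound 2 (0.62 log units; beyond the scatter). Compound 3 differs from compound 1 by chloro in place of hydrogen on an aromatic carbon, with a 3.0-fold higher number from compound 1 to compound 3 (0.48 log units; beyond the scatter).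

Compound 4, `CC#C[C@@H](CC(=O)O)c1ccc(OC[C@H]2COc3cc(Br)c(Cl)cc3O2)cc1`, has not yet been measured. It differs from compound 3 by bromo in place of chloro on an aromatic carbon. This is the same kind of change as that from compound 1 to compound 2, though here the place is ortho to a chloro group, which it is not in compound 1. Because the earlier step was a 4.2-fold higher number from compound 1 to compound 2 (0.62 log units; beyond the scatter), a step of similar size is expected, a 3.0-fold higher number from compound 3 to compound 4 (0.48 log units; beyond the scatter). Compound 4 is thus expected to give about 450 nM, likely between 200 nM and 1100 nM.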

Compound 4, half-maximal effective concentration: 200 nM
Estimate against measurement, compound 4: 2.3-fold (0.35 log units) above; low and high end bracket the measured number.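

In this assay, bromo in place of chloro on an aromatic carbon gave a 1.3-fold higher number from compound 3 to compound 4 (0.12 log units; within the scatter), so the change did not carry over at one fixed size from the core of compound 1 to the core of compound 3: the same change on two cores in this assay, a 4.2-fold higher number (0.62 log units; beyond the scatter) from compound 1 to compound 2 and a 1.3-fold higher number (0.12 log units; within the scatter) from compound 3 to compound 4, 3.2-fold (0.50 log units) apart, beyond the scatter of two such steps The added bromo gave a 4.0-fold higher number from compound 1 to compound 4 (0.60 log units; beyond the scatter). This shows that the step differed between these two pairs, but it does not show why, and two pairs give no rule for other cores.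

The compounds shown leave open what a fluoro, methoxy or nitrile group would do at these places on the aromatic ring. They also leave open whether an amine there would follow either step.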